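Carboxyphenyl placement on the amide nitrogen: compound 3 to compound 4

The compounds below may be only part of what the source reports. "The series", "measured", "known", "first", "only" and "open" are said of these compounds alone.

Compound 1 `CCCCCCCCCCOc1cccc(OCCCCCCON=C(c2ccc(C(=O)O)cc2)c2ccc(C(=O)O)cc2)c1` gives "not determined" (no result reported)
Compound 2 `CCCCCCCCCCOc1cc(OCCCCCCCCCC)cc(OCCCCCC(=O)N(c2ccc(C(=O)OC)cc2)c2ccc(C(=O)OC)cc2)c1` gives 16%
Compound 3 `O=C(O)c1ccc(N(C(=O)CCCCCBr)c2cccc(C(=O)O)c2)cc1` gives 19%

In an assay on isolated protein for binding affinity to P-selectin (Homo sapiens), read by ELISA, tested at 500 uM (a lower number here means less inhibition, a higher number more inhibition at the concentration tested (going by the name of the read-out)), compound 3 stands at 19%, the higher of the two numbers reported. Compound 2 gives 16% in this assay, a gap that lies within the scatter, so no order between compound 2 and compound 3 can be stated. For compound 1 no result was reported.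

Compound 4 `O=C(O)c1ccc(N(C(=O)CCCCCBr)c2ccc(C(=O)O)cc2)cc1` differs from compound 3 by 4-carboxyphenyl in place of 3-carboxyphenyl on an amide-type nitrogen. No pair of measured compounds differs in one place, so the size of this step has no direct reference among the numbers shown. The step expected in this assay is a number 1 percentage points higher from compound 3 to compound 4 (within the scatter), none beyond the scatter. Compound 4 is therefore expected to give 20%, with a range from 5% to 38%.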

Compound 4, a percentage reported as inhibition, at one concentration (the size of the read-out at that concentration, not a potency): 12%
Compound 4: middle estimate off by 8 percentage points, on the high side; the measured number falls inside the stated range.
By their numbers in this assay, from the lowest: compounds 4, 2 and 3 (each within the scatter of the next).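

In this assay, within the data shown here, the exchange of 3-carboxyphenyl for 4-carboxyphenyl on the amide-type nitrogen gives a number 7 percentage points lower from compound 3 to compound 4 (within the scatter) and this is the first single-place comparison. It shows that, at the concentration tested, the two placements cannot be told apart, and both compounds give only modest inhibition. Nothing measured here accounts for the size of this step. The compounds shown leave open whether a tetrazole in place of either carboxylic acid would change the read-out. They also leave open what an amine or a longer chain in place of the bromohexanoyl chain would do.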